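Notes on the saturated ring carbon substituent in the series

A few compounds are considered here, and "the series" means these few. Any claim that something is new, unique, unknown or untested is made for them only; others in the source may bear on it.

Going by the values given here, compound 3 `N#CC1=C(N)N(c2ccc(S(N)(=O)=O)cc2)C2=C(CCCC2)C1/C=C/c1ccccc1` gives 90% in a functional assay on Ehrlich cells (Mus musculus) for cytotoxicity, read by trypan blue exclusion, with a stated time of 2 h, tested at 50 ug/mL (a higher number here means a stronger effect of the compound at the concentration tested, a lower number a weaker effect), the highest of the three numbers so far. Compound 1 `Cc1ccc(C2C(C#N)=C(N)N(c3ccc(S(N)(=O)=O)cc3)C3=C2CCCC3)cc1` gives 80% in this assay, and a number 10 percentage points higher from compound 1 to compound 3 (within the scatter). Compound 2 `N#CC1=C(N)N(c2ccc(S(N)(=O)=O)cc2)C2=C(CCCC2)C1c1ccccc1O` gives 50% in this assay, and a number 40 percentage points higher from compound 2 to compound 3 (beyond the scatter). Compound 4 `N#CC1=C(N)N(c2ccc(S(N)(=O)=O)cc2)C2=C(CCCC2)C1c1ccc(Cl)c(Cl)c1` carries 3,4-dichlorophenyl in place of 2-phenylethenyl on a saturated ring carbon. Among the compounds with values here, no measured step trades 2-phenylethenyl for a chlorinated aryl group. The steps at the saturated ring carbon are a number 30 percentage points lower from compound 1 to compound 2 (beyond the scatter), a number 10 percentage points higher from compound 1 to compound 3 (within the scatter) and a number 40 percentage points higher from compound 2 to compound 3 (beyond the scatter); only the 2-hydroxyphenyl compound 2 fell clearly. Compound 4 resembles compound 1 in bearing an aryl group without a hydroxyl, and compound 1 gives 80%. For compound 4 the expected step is therefore a number 10 percentage points lower from compound 3 to compound 4 (within the scatter), within the scatter. Compound 4 is estimated at 80%, with a range from 60% to 95%.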

Compound 4, a percentage reported as activity, at one concentration (the size of the read-out at that concentration, not a potency): 50%
For compound 4 the middle estimate is 30 percentage points above the measured one, outside the stated range (below it).
By their numbers in this assay, from the lowest: compounds 2 and 4 (each within the scatter of the next); then compounds 1 and 3 (each within the scatter of the next).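

In this assay, the fall at this position is no longer tied to the hydroxyl of compound 2, since 3,4-dichlorophenyl carries none and the printed step is no change at the digits printed from compound 2 to compound 4 (within the scatter). Aryl groups on the saturated ring carbon also separate among themselves, with a number 30 percentage points lower from compound 1 to compound 4 (beyond the scatter), while the exchange for 2-phenylethenyl gives a number 40 percentage points lower from compound 3 to compound 4 (beyond the scatter). No evidence at hand accounts for these steps.

Left open is whether an unsubstituted phenyl or a cyclohexyl group on the saturated ring carbon would stand with compounds 1 and 3 or with compounds 2 and 4.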